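This account rests on a few compounds, and the source may have more. Where it says the series, first, only, none or still open, it means among the compounds named here.

Measured so far in an assay on cells for inhibition of interleukin-5 receptor subunit alpha (Mus musculus), read by WST assay, with a stated time of 48 h, in the presence of a further agent that is not named here; a higher number here means a weaker inhibitor, a lower number a stronger inhibitor:
compound 1 `OCCNCc1nc2c(OCC3CCCCC3)cccc2[nH]1`: 20000 nM
compound 2 `CCC(CO)NCc1nc2c(OCC3CCCCC3)cccc2[nH]1`: 3500 nM
compound 3 `OCC(CC1CCCCC1)NCc1nc2c(OCC3CCCCC3)cccc2[nH]1`: 5000 nM

Compound 2 gives the lowest number of the three in this assay; its gap to compound 3 sits within the scatter, whereas the step of a 5.7-fold lower number from compound 1 to compound 2 (0.76 log units; beyond the scatter) lies beyond it. The change to compound 4 `c1ccc(CNCc2nc3c(OCC4CCCCC4)cccc3[nH]2)cc1` is benzyl in place of 1-(hydroxymethyl)propyl on an amine nitrogen. Among the compounds with values here, no measured step removes the hydroxymethyl group, which every measured compound carries, and none brings an aromatic ring onto this nitrogen, so the precedent is indirect. The steps of a 5.7-fold lower number from compound 1 to compound 2 (0.76 log units; beyond the scatter) and a 4.0-fold lower number from compound 1 to compound 3 (0.60 log units; beyond the scatter) show that adding carbon on the chain carbon bound to the amine nitrogen lowers the number, and the step of a 1.4-fold higher number from compound 2 to compound 3 (0.15 log units; within the scatter) shows that a larger group further out changes little. Within the data shown here, compound 4 gains ring carbon but gives up the hydroxymethyl group, for which no step gives a precedent. The expectation for the step from compound 2 is therefore a modest rise in this assay, estimated as a 1.7-fold higher number from compound 2 to compound 4 (0.23 log units; within the scatter), with wide uncertainty. The estimate for compound 4 in this assay is 6000 nM, expected to fall between 1500 nM and 25000 nM.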

Compound 4, half-maximal inhibitory concentration: > 30000 nM
Compound 4 was reported as a limit (the forecaster's own chance of this, stated with the estimate: 15%); middle value at least 5.0-fold (0.69 log units) from the limit.
By their numbers in this assay, from the lowest: compounds 2 and 3 (each within the scatter of the next); then compound 1. At a limit, above all of these: compound 4.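

In this assay compound 4 is reported only as a limit: the limit of > 30000 nM in this assay, at which 1 of the 4 values shown sits. Benzyl in place of 1-(hydroxymethyl)propyl on the amine nitrogen gives an at least 8.5-fold higher number from compound 2 to compound 4 (0.93 log units; beyond the scatter), the one step here that raises the number beyond the scatter, so compound 4 goes against the lowering seen when carbon was added in compound 2 and compound 3. Phenyl in place of hydroxymethyl gives an at least 1.5-fold higher number from compound 1 to compound 4 (0.17 log units; that floor lies within the scatter), a floor within the scatter, so the true gap remains unknown, but this change shows none of that lowering.

Compound 4 loses the hydroxymethyl group and gains the aromatic ring in one change, and the compounds shown do not separate the two. A plain butyl chain on this nitrogen, or a chain that keeps hydroxymethyl and ends in phenyl, would separate them.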